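Cyclopentyl amide of the dimethoxy indane series

This account rests on a few compounds, and the source may have more. Where it says the series, first, only, none or still open, it means among the compounds named here.

Compound 2 `COc1cc2c(cc1OC)C(CC(=O)NC(C)C)CC2` carries an isopropyl group on the amide nitrogen of the shared core. In a functional assay on the whole organism (strain Wistar) for inhibition, with Rattus norvegicus as the target, read by paw edema, with stated times of 60 min and 6 h, at a dose of 100 mg/kg by the oral route (a higher number here means more inhibition at the dose given (going by the name of the read-out), a lower number less inhibition), compound 2 gives 37%, the largest of the three numbers measured, though its margin over compound 3 lies within the scatter. Compound 1 `CNC(=O)CC1CCc2cc(OC)c(OC)cc21`, the methyl amide, gives 24.1% in this assay, and compound 3 `CCCCCNC(=O)CC1CCc2cc(OC)c(OC)cc21`, the pentyl amide, gives 35.2%. The rise a number 12.9 percentage points higher from compound 1 to compound 2 (beyond the scatter) and the rise a number 11.1 percentage points higher from compound 1 to compound 3 (beyond the scatter) are both modest and beyond the scatter, whereas a number 1.8 percentage points lower from compound 2 to compound 3 (within the scatter) is not.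

Compound 4 `COc1cc2c(cc1OC)C(CC(=O)NC1CCCC1)CC2` differs from compound 2 in one place: cyclopentyl in place of isopropyl on an amide-type nitrogen. Within the data shown here, the step that bears most directly on it is the one from compound 2 to compound 3, where a larger alkyl group on the same nitrogen left the read-out within the scatter. The steps from compound 1 show that going from a small to a larger amide substituent helped modestly, but nothing in the three measured compounds shows a further gain once isopropyl is present. Compound 4 is therefore expected to sit close to compound 2, with a step of a number 1 percentage points higher from compound 2 to compound 4 (within the scatter) that stays within the scatter. Compound 4 is estimated at 38% in this assay, expected to fall between 28% and 48%.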

Compound 4, a percentage reported as inhibition, in the whole organism at one dose (the size of the read-out at that dose, not a potency): 40.7%
The estimate for compound 4 lay 2.7 percentage points below the measured number, within the range that was stated.
By their numbers in this assay, from the lowest: compound 1; then compounds 3, 2 and 4 (each within the scatter of the next).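

A ring on this nitrogen is accepted as readily as the open groups: in this assay the change to cyclopentyl gives a number 3.7 percentage points higher from compound 2 to compound 4 (within the scatter) and, against the straight chain, a number 5.5 percentage points higher from compound 3 to compound 4 (within the scatter) so the branched, straight and cyclic substituents cannot be told apart in this read-out. The only step beyond the scatter remains the one that starts from the small methyl group, here a number 16.6 percentage points higher from compound 1 to compound 4 (beyond the scatter) and all three larger substituents now stand apart from compound 1 in the same modest way, with no listed compound going against this. No measured evidence bears on why the ring is accepted on this nitrogen.

Going by these compounds, it remains open whether the same level holds for a larger ring such as cyclohexyl, for an aromatic group such as phenyl or benzyl, or for a chain ending in an amine or a carboxylic acid on the same amide nitrogen. The read-out is also the size of the effect at one dose and not a potency, so any order among compound 2, compound 3 and compound 4 stays undecided.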